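The source may hold more compounds than are shown below. What is called first, only, known or untested is meant among the compounds shown, and "the series" means these compounds.

Of the compounds shown here, two have numbers so far in a physicochemical assay for lipophilicity, at pH 7.4; a lower number here means a more polar compound, a higher number a more lipophilic compound. Compound 1 `CC(C)CN(c1ccc(C#N)cc1)S(=O)(=O)c1ccc2c(c1)C(O)CC(C1CCOCC1)O2` gives 3.07 in this assay, the lower of the two. Compound 2 `CCc1ccc(N(CC(C)C)S(=O)(=O)c2ccc3c(c2)C(O)C[C@@H](C2CCOCC2)O3)cc1` gives 4.12 in this assay, a gap beyond the scatter. Compound 3 `CC(C)CN(c1cc2ccccc2s1)S(=O)(=O)c1ccc2c(c1)C(O)CC(C1CCOCC1)O2` has not been measured in this assay. It differs from compound 1 in one place: 1-benzothiophen-2-yl in place of 4-cyanophenyl on a sulfonamide nitrogen. Within the data shown here, no measured pair shows this change, so its size is not known from these data. A rise beyond the scatter is expected in this assay, a number 1.33 log units higher from compound 1 to compound 3 (beyond the scatter). Compound 3 is estimated at 4.4 in this assay, with a range from 3.9 to 4.9.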

Compound 3, distribution coefficient: 3.92
Compound 3: middle estimate off by 0.48 log units, on the high side; low and high end bracket the measured number.
By their numbers in this assay, from the lowest: compound 1; then compounds 3 and 2 (each within the scatter of the next).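

Among these compounds, on a sulfonamide nitrogen, 1-benzothiophen-2-yl in place of 4-cyanophenyl gives the only step read so far in this assay, with a number 0.85 log units higher from compound 1 to compound 3 (beyond the scatter) as a modest change beyond the scatter. This position therefore moves the number in this assay, with the rest of compound 1 unchanged. Nothing at hand accounts for the size of this step.

Still open, going by these compounds, is how a 4-substituted phenyl group other than 4-cyanophenyl compares in a single-place step. On these data alone, it is also open whether an amine or a carboxylic acid on that phenyl ring would take the number below that of compound 1 at 3.07 in this assay.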